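A few compounds are considered here, and "the series" means these few. Any claim that something is new, unique, unknown or untested is made for them only; others in the source may bear on it.

Measured so far:
- compound 1 `O=C(O)c1cccc(C2CC2c2ccc(OCc3c(-c4c(Cl)cccc4Cl)noc3C3CC3)cc2Cl)c1`: 87%
- compound 2 `CO[C@]1(c2ccc(OCc3c(-c4c(Cl)cccc4Cl)noc3C3CC3)cc2Cl)C[C@H](c2cccc(C(=O)O)c2)C1`: 75%

In an assay on HEK293 cells for agonist activity at Bile acid receptor (Homo sapiens) (a higher number here means a larger maximal response, a lower number a smaller maximal response), compound 1 gives 87% and stands highest of the two numbers in hand. The nearest is compound 2, which in this assay gives 75%, a gap that lies beyond the usual scatter of this measurement. Among the measured compounds shown here, no single-point step between these two measured compounds exists, so nothing more is taken from that pair than what the two values show.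

The next compound in the series is compound 3 `O=C(O)c1ccc(C2CC2c2ccc(OCc3c(-c4c(Cl)cccc4Cl)noc3C3CC3)cc2Cl)cn1`. It follows from compound 1 by one change: 6-carboxypyridin-3-yl in place of 3-carboxyphenyl on a saturated ring carbon. The change sits on a saturated ring carbon of the three-membered non-aromatic ring of carbon only, next to the ring atom that bears the large group; the rest of the shared core is kept.

For the measured compounds named here, no measured step of this kind is in hand, so the expectation rests on compound 1 alone. Exchanging 3-carboxyphenyl for 6-carboxypyridin-3-yl is expected to leave the maximal response in this assay roughly where compound 1 stands, with a step of a number 7 percentage points lower from compound 1 to compound 3 (within the scatter) that is estimated to fall within or only slightly beyond the scatter, if anything downward. Compound 3 is therefore estimated at 80% in this assay, in a range from 58% to 100%.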

Compound 3, largest response reached (reported as efficacy), in percent of the reference or control that the assay uses: 68%
For compound 3 the middle estimate is 12 percentage points above the measured one, within the range that was stated.
By their numbers in this assay, from the lowest: compounds 3 and 2 (each within the scatter of the next); then compound 1.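

In this assay, among the compounds shown here, 6-carboxypyridin-3-yl in place of 3-carboxyphenyl on a saturated ring carbon of the three-membered ring gives a number 19 percentage points lower from compound 1 to compound 3 (beyond the scatter) and is the first step that can be read at a single place. It shows that the maximal response depends on the aromatic ring carrying the carboxy group at this position, even with that group retained and the rest of the shared core unchanged, so the two groups are not interchangeable here. No measurement available for these compounds accounts for the step.

The exchange alters both the ring, which gains a hetero atom, and the numbering of the carboxy group in the name, and this one step does not separate the two; a 4-carboxyphenyl group or a 5-carboxypyridin-3-yl group would bear on that question. Also open, going by these compounds, is whether the carboxylic acid itself is needed at this place, which a tetrazole or a primary amide on the same ring would address, and whether the same exchange behaves alike on other linkers of the series.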